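Working notes on a fourth variant of the shared core

The compounds below may be only part of what the source reports. "The series", "measured", "known", "first", "only" and "open" are said of these compounds alone.

Measured so far:
compound 1 `Cc1cc(C#N)nc(NNC(=O)Nc2cc(Cl)nc(Cl)c2)c1`, > 23000 nM
compound 2 `Cc1cc(CO)nc(NNC(=O)Nc2cc(Cl)nc(Cl)c2)c1`, > 23000 nM
compound 3 `CCOC(=O)c1cc(C)cc(NNC(=O)Nc2cc(Cl)nc(Cl)c2)n1`, > 23000 nM

In a functional assay on CHO cells for agonist activity at sphingosine 1-phosphate receptor 2 (Homo sapiens), read by fluorescence and calcium flux, with a stated time of 3 min (on this read-out lower numbers stand for stronger inhibition and higher numbers for weaker inhibition), compound 1 gives > 23000 nM, which is a limit of the assay and not a number. Compound 2 likewise gives > 23000 nM, again a limit. Compound 3 gives > 23000 nM, also a limit. Compound 3 therefore stands where the other two stand: all three values sit at the limit of > 23000 nM in this assay, at which 3 of the 3 values shown sit, and none of them is a number. The steps among them are a step that the two limits leave unreadable from compound 1 to compound 2, a step that the two limits leave unreadable from compound 1 to compound 3 and a step that the two limits leave unreadable from compound 2 to compound 3; with both ends at the limit, none of them can be sized.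

Compound 4 `Cc1cc(NNC(=O)Nc2cc(Cl)nc(Cl)c2)nc(-c2cnn(C)c2)c1` carries the change (1-methyl-1H-pyrazol-4-yl in place of ethoxycarbonyl on an aromatic carbon). Among the measured compounds shown here, the steps that bear on this position are the three just named, and all are unreadable, so they give no direction for the new step. What they do show is that three different groups at this position all leave the compound at the limit. The step from compound 3 to compound 4 is therefore expected to be an at least 1.1-fold lower number from compound 3 to compound 4 (0.06 log units; that floor lies within the scatter), with no direction readable from the data. Compound 4 is expected to give 20000 nM in this assay, with a range from 5000 nM to 60000 nM, and most likely again only a limit.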

Compound 4, half-maximal inhibitory concentration: > 23000 nM
Compound 4: only a limit was reported; the forecaster's own chance of this, stated with the estimate: 70%; at least 1.1-fold (0.06 log units) between middle value and limit.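

In this assay compound 4 gives > 23000 nM, which is a limit and not a number. The steps to compound 4 from compound 1, compound 2 and compound 3 cannot be read, since all four compounds sit at one limit: the limit of > 23000 nM in this assay, at which 4 of the 4 values shown sit.

The compounds shown leave open whether any group at this position gives a measurable value in this assay.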